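This account rests on a few compounds, and the source may have more. Where it says the series, first, only, none or still open, it means among the compounds named here.

For the measured compounds named here, compound 2 `COC(=O)c1ccccc1-c1cnc(C(=O)CCCCCCc2ccccc2)o1` is the stronger of the two compounds measured so far: in an assay (Rattus norvegicus) for inhibition of Fatty-acid amide hydrolase 1 (Homo sapiens) (on this read-out higher numbers stand for weaker inhibition and lower numbers for stronger inhibition), compound 2 gives 60 nM, the lowest of the two numbers, and its nearest neighbour is compound 1 `Nc1ccccc1-c1cnc(C(=O)CCCCCCc2ccccc2)o1`, which in this assay gives 750 nM. Going by the values given here, the only step between measured compounds is a 13-fold lower number from compound 1 to compound 2 (1.10 log units; beyond the scatter), a large move that shows this position on the six-membered ring of carbon only to matter for the read-out.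

Compound 3 `O=C(CCCCCCc1ccccc1)c1ncc(-c2ccccc2F)o1` is not yet measured. It differs from compound 2 in one place: fluoro in place of methoxycarbonyl on an aromatic carbon. Among the compounds with values here, no measured step exchanges methoxycarbonyl for fluoro, so the bearing of the single known step is indirect; it shows only that a change at this aromatic carbon can shift the number well beyond the scatter. Since the group that leaves is the one whose arrival brought the large gain in compound 2, compound 3 is expected to lose part of that gain, with the expected step being a 4.2-fold higher number from compound 2 to compound 3 (0.62 log units; beyond the scatter). For compound 3 the estimated value in this assay is 250 nM, within a range from 80 nM to 800 nM.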

Compound 3, inhibition constant: 110 nM
Compound 3: middle estimate off by 2.3-fold (0.36 log units), on the high side, and the stated range covers the measured number.
By their numbers in this assay, from the lowest: compounds 2 and 3 (each within the scatter of the next); then compound 1.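

In this assay, the exchange of methoxycarbonyl for fluoro gives a 1.8-fold higher number from compound 2 to compound 3 (0.26 log units; within the scatter), so at this aromatic carbon a single fluorine atom stands level with the four heavy atoms of methoxycarbonyl, and the two hydrogen-bond acceptors counted in that group are not required for a number in this range. For the compounds shown here, the other new step, a 6.8-fold lower number from compound 1 to compound 3 (0.83 log units; beyond the scatter), shows that the low number is not tied to methoxycarbonyl alone: of the three groups seen at this place, amino is the only one whose number is set apart from the others, and the large step from the earlier pair can no longer be read as a gain specific to methoxycarbonyl. No measurement given here explains why amino stands apart from the other two groups.

The compounds shown leave open how a plain hydrogen, a chloro group or a carboxylic acid on this aromatic carbon would compare with fluoro and methoxycarbonyl, and so whether amino lowers the inhibition or the other two raise it. They also leave open whether the level standing of fluoro and methoxycarbonyl would hold with a shorter chain in place of the one shared by all three compounds.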